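Replacing the nitrile on the ethyl side chain

The source may report more compounds than this note shows. Statements on the series, on what has been measured and on what is new or still open speak of the compounds shown alone.

Values in a functional assay (trachea) with Cavia porcellus as the target (a lower number here means that less compound is needed, a higher number that more compound is needed for the effect), so far, with the next compound
- compound 1 `CCCn1c(=O)n(C)c(=O)c2c1ncn2CC#N` gives 35300 nM
- compound 2 `CCCn1c(=O)n(C)c(=O)c2c1ncn2CCC#N` gives 27600 nM
- compound 3 `CCCn1c(=O)n(C)c(=O)c2c1ncn2CCN(C)C` is not yet measured

Compound 2 at 27600 nM stands level with compound 1 within the scatter, and no other values are available.

The change from compound 2 to compound 3 is dimethylamino in place of cyano on a saturated chain carbon, two bonds along the chain from an aromatic nitrogen and in words it is dimethylamino in place of cyano on a saturated chain carbon, two bonds along the chain from an aromatic nitrogen.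

Within the data shown here, the only measured step is a 1.3-fold lower number from compound 1 to compound 2 (0.11 log units; within the scatter) and it bears on this change only indirectly, since both compounds keep the nitrile. Among the measured compounds shown here, no measured compound carries dimethylamino, so no shift beyond the scatter is expected in this assay and the range stays wide. The expected outcome is a 1.1-fold higher number from compound 2 to compound 3 (0.04 log units; within the scatter) on present evidence. Compound 3 is estimated at 30000 nM with an expected range of 10000 nM to 90000 nM for now.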

Compound 3, half-maximal effective concentration: > 100000 nM
Compound 3: only a limit was reported; the forecaster's own chance of this, stated with the estimate: 10%; at least 3.3-fold (0.52 log units) between middle value and limit.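

In this assay compound 3 gives > 100000 nM as a limit of the assay, not as a number. Compound 1 and compound 2 stood level within the scatter, so the nitrile series alone showed no response at this position, whereas the exchange of cyano for dimethylamino gives an at least 3.6-fold higher number from compound 2 to compound 3 (0.55 log units; beyond the scatter) and the comparison with the shorter nitrile gives an at least 2.8-fold higher number from compound 1 to compound 3 (0.45 log units; beyond the scatter). Both steps therefore show that the end group on this chain matters, but each fixes only a lower bound on its size, because compound 3 stands at the end of the readable range: the limit of > 100000 nM in this assay, at which 1 of the 3 values shown sits.

On these data alone, how far compound 3 actually lies from the nitriles stays open. Also open, as far as these compounds go, is whether the shift is specific to dimethylamino or would also appear with a primary amine, a carboxylic acid or a longer chain at this place.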